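The compounds below may be only part of what the source reports. "The series", "measured", "known", "first", "only" and "open" are said of these compounds alone.

Compound 1 `O=C(Nc1ccc(I)cc1)N1CCC[C@H]1c1nc(-c2ccccc2)no1`: > 50000 nM
Compound 2 `O=C(Nc1ccc(C(F)(F)F)cc1)N1CCC[C@H]1c1nc(-c2ccccc2)no1`: > 50000 nM
Compound 3 `O=C(Nc1ccc(Cl)cc1)N1CCC[C@H]1c1nc(-c2cccc(F)c2)no1`: > 50000 nM

All three results in an ADME assay on MCF-10A cells (Homo sapiens) for inhibition, with a stated time of 48 h (a lower number here means a stronger inhibitor, a higher number a weaker inhibitor), are limits of the assay and not numbers, and the evidence on them amounts to the limit of > 50000 nM in this assay, at which 3 of the 3 values shown sit. Compound 3 therefore has no exact position, and its entry of > 50000 nM is only a limit.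

Compound 4 `O=C(Nc1ccc(Cl)cc1)N1CCC[C@H]1c1nc(-c2ccc(Cl)cc2)no1` has 4-chlorophenyl in place of 3-fluorophenyl on an aromatic carbon of a five-membered aromatic ring with 2 nitrogen and 1 oxygen (4-chlorophenyl in place of 3-fluorophenyl on an aromatic carbon). Among the compounds with values here, the only measured step, a step that the two limits leave unreadable from compound 1 to compound 2, puts trifluoromethyl in place of iodo on an aromatic carbon. It is a different change and gives no size to carry over.

The expectation therefore rests on compound 3, whose > 50000 nM is a limit, and no direction can be supported. The expected step in this assay is a number no higher from compound 3 to compound 4 (the limit leaves the size open), with no change expected beyond the scatter. The estimate for compound 4 is 50000 nM, with an expected range from 20000 nM to 100000 nM, and a report of only a limit is the likeliest outcome.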

Compound 4, half-maximal inhibitory concentration: > 50000 nM
Compound 4: only a limit was reported (the forecaster's own chance of this, stated with the estimate: 85%); the middle value lies on the limit itself.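

In this assay compound 4 gives > 50000 nM as a limit and not a number. Within the data shown here, compound 3 also stands at a limit, so no step from compound 3 to compound 4 can be read. In this assay the compounds shown leave open whether any change to the shared core gives a measurable value, as all rest at one limit: the limit of > 50000 nM in this assay, at which 4 of the 4 values shown sit.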